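The compounds below may be only part of what the source reports. "The series", "measured", "known", "first", "only" and "open" are said of these compounds alone.

This study follows a small set of compounds that share one core and differ only in the aromatic group attached to it. In an assay for binding affinity to dual specificity mitogen-activated protein kinase kinase 4 (Homo sapiens), read by KINOMEscan, tested at 100 nM (a higher number here means a weaker effect of the compound at the concentration tested, a lower number a stronger effect), compound 1 `CCCS(=O)(=O)Nc1ccc(F)c(C(=O)c2n[nH]c3ncc(-c4ccccc4N)cc23)c1F` gives 23%. Compound 2 `CCCS(=O)(=O)Nc1ccc(F)c(C(=O)c2n[nH]c3ncc(-c4cccc(N)c4)cc23)c1F` carries 3-aminophenyl where compound 1 carries 2-aminophenyl. In this assay, for the measured compounds named here, compound 2 gives 1.6%, the lowest of the two numbers measured so far; the move a number 21.4 percentage points lower from compound 1 to compound 2 (beyond the scatter) is the only step recorded.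

Compound 3 `CCCS(=O)(=O)Nc1ccc(F)c(C(=O)c2n[nH]c3ncc(-c4ccc(Cl)cc4Cl)cc23)c1F` is not yet measured. It differs from compound 2 by 2,4-dichlorophenyl in place of 3-aminophenyl on an aromatic carbon. Going by the values given here, no measured step tests this kind of exchange: the single recorded step only moved an amino group from one place on the phenyl to another, and it changed this assay by a modest amount. Compound 2 already sits near the bottom of the scale, so little room remains for a lower number, and a change this different in kind leaves the direction open. A step upward is expected, of uncertain size, a number 10.4 percentage points higher from compound 2 to compound 3 (beyond the scatter). The value for compound 3 is therefore estimated at 12%, with a range from 1% to 45%.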

Compound 3, a percentage reported as activity, at one concentration (the size of the read-out at that concentration, not a potency): 22%
Compound 3: middle estimate off by 10 percentage points, on the low side; the measured number falls inside the stated range.
By their numbers in this assay, from the lowest: compound 2; then compounds 3 and 1 (each within the scatter of the next).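

Exchanging 3-aminophenyl for 2,4-dichlorophenyl on this aromatic carbon, two atoms from the ring nitrogen, weakens the effect in this assay (a number 20.4 percentage points higher from compound 2 to compound 3 (beyond the scatter)), so the low number is not kept across a change of this kind. The comparison with the other amino compound (a number 1 percentage points lower from compound 1 to compound 3 (within the scatter)) shows that 2,4-dichlorophenyl and 2-aminophenyl cannot be told apart here, even though one group carries two chlorines and the other an amino group. Among these three compounds, 3-aminophenyl alone stands apart, and the presence of an amino group on the phenyl is not enough by itself, as the 2-aminophenyl of compound 1 goes against any such rule.

No measurement at hand explains why these groups differ. Still open, going by these compounds, is whether the low number depends on the amino group itself, or whether a hydroxyl group, a methyl group or a single chlorine in its place on that phenyl would hold the number as low.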